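The compounds below may be only part of what the source reports. "The series", "measured", "known", "first", "only" and "open" are said of these compounds alone.

- compound 1 `C/C(=N\NC(=S)Nc1ccc(I)cc1)c1ccccn1`: 6.61 nM
- compound 2 `C/C(=N/NC(=S)Nc1cccc([N+](=O)[O-])c1)c1ccccn1`: 38 nM
- compound 3 `C/C(=N\NC(=S)Nc1ccccc1F)c1ccccn1`: 0.39 nM

In a functional assay on MCF7 cells (Homo sapiens) for cytotoxicity, read by MTT assay, with a stated time of 48 h (on this read-out higher numbers stand for weaker inhibition and lower numbers for stronger inhibition), compound 1 stands in the middle of the three: its number is lower than that of compound 2 and higher than that of compound 3, with both gaps beyond the usual scatter. Compound 4 `C/C(=N\NC(=S)Nc1ccc(F)cc1)c1ccccn1` is compound 1 with one change: fluoro in place of iodo on an aromatic carbon, para to a large group (fluoro in place of iodo on an aromatic carbon). Going by the values given here, no measured pair shows this swap directly, so the guidance is thin. Compound 3 also carries a fluoro group and gives 0.39 nM, so a moderate drop in the number is expected in this assay, probably beyond the scatter but quite uncertain. The estimated change is a 3.3-fold lower number from compound 1 to compound 4 (0.52 log units; beyond the scatter). For compound 4 the expected value is 2 nM, with an estimated range of 0.3 nM to 12 nM.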

Compound 4, half-maximal inhibitory concentration: 1.2 nM
Compound 4: the middle estimate sits 1.7-fold (0.22 log units) above what was measured; low and high end bracket the measured number.
By their numbers in this assay, from the lowest: compound 3; then compound 4; then compound 1; then compound 2.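

In this assay, placing fluoro instead of iodo on the aromatic carbon para to a large group gives a 5.5-fold lower number from compound 1 to compound 4 (0.74 log units; beyond the scatter). This is the first direct single-change comparison among these compounds, and it shows that the halogen at this position alone can shift the number beyond the usual scatter. Nothing measured here gives a reason for this step.

The compounds shown leave open whether chloro or bromo at this position would give a number between those of compound 4 and compound 1. On these data alone, how an amine or a methoxy group would behave there also remains open.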